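The compounds below may be only part of what the source reports. "The series", "measured", "known", "first", "only" and "open" are said of these compounds alone.

Measured so far:
Compound 1 `CC(=O)Nc1ccc(S(=O)(=O)NNc2ccc(F)cc2)cc1`: 609 nM
Compound 2 `CC(=O)Nc1ccc(S(=O)(=O)NNc2ccc(Cl)cc2)cc1`: 142 nM
Compound 3 `CC(=O)Nc1ccc(S(=O)(=O)NNc2cccc(Br)c2)cc1`: 7560 nM

All three share one core and differ only in the ring carried on the amine nitrogen. In an assay on HeLa cells for inhibition of Indoleamine 2,3-dioxygenase 1 (Homo sapiens), read by spectrophotometry, with a stated time of 24 h (a lower number here means that less compound is needed, a higher number that more compound is needed for the effect), compound 3 gives the highest number of the three: a 12-fold higher number from compound 1 to compound 3 (1.09 log units; beyond the scatter) and a 53-fold higher number from compound 2 to compound 3 (1.73 log units; beyond the scatter), both beyond the scatter. Within the ring itself, a 4.3-fold lower number from compound 1 to compound 2 (0.63 log units; beyond the scatter) shows that swapping one halogen for another at the same aromatic carbon can move the number well beyond the scatter.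

Compound 4 `CC(=O)Nc1ccc(S(=O)(=O)NNc2ccc(F)c(Br)c2)cc1` keeps everything of compound 3 and adds one atom: fluoro in place of hydrogen on an aromatic carbon. For the measured compounds named here, no measured step adds a fluoro to a ring that already carries a bromo group. What bears on it is that compound 1, whose ring carries a fluoro at the same aromatic carbon, gives 609 nM in this assay, while compound 3 gives 7560 nM. A step toward a lower number is therefore expected, of moderate size, estimated as a 3.0-fold lower number from compound 3 to compound 4 (0.48 log units; beyond the scatter). For compound 4 the expected value in this assay is 2500 nM, with a range from 800 nM to 8000 nM.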

Compound 4, half-maximal effective concentration: 2490 nM
For compound 4 the middle estimate is 1.0-fold (0.00 log units) above the measured one, and the stated range covers the measured number.
By their numbers in this assay, from the lowest: compound 2; then compound 1; then compound 4; then compound 3.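

Adding fluoro lowers the number even on a ring that already carries a bromo group, giving a 3.0-fold lower number from compound 3 to compound 4 (0.48 log units; beyond the scatter) for this single added atom. For the compounds shown here, the bromo group can now also be read on its own: adding it to the fluoro-bearing ring gives a 4.1-fold higher number from compound 1 to compound 4 (0.61 log units; beyond the scatter) and so moves the number the other way, an effect the earlier comparisons could not isolate because they changed the halogen and its place together. Nothing available here explains either shift.

The compounds shown leave open whether chloro at the fluoro-bearing carbon would also lower the number when the bromo group is present. They also leave open how a methoxy group or an amine would behave at that carbon.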